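Replacing the methoxycarbonyl group of compound 1

A few compounds are considered here, and "the series" means these few. Any claim that something is new, unique, unknown or untested is made for them only; others in the source may bear on it.

Compound 1 `CCc1cccc2c(OC)c(-c3occ(C)c3C(=O)OC)ccc12` is the reference point of this small set. Going by the values given here, in a functional assay on ZR-75-1 cells (Homo sapiens) for cytotoxicity, read by MTT assay, with a stated time of 72 h (a higher number here means that more compound is needed for the effect, a lower number that less compound is needed), compound 1 gives 1.3 ug/mL, the lowest of the three numbers so far. Compound 2 `CCc1cccc2c(OC)c(-c3occ(C)c3C(=S)OC)ccc12` gives 5.8 ug/mL in this assay, and compound 3 `CCc1cccc2c(OC)c(-c3occ(C)c3COC)ccc12` gives 9.7 ug/mL. The two steps away from compound 1 are a 4.5-fold higher number from compound 1 to compound 2 (0.65 log units; beyond the scatter) and a 7.5-fold higher number from compound 1 to compound 3 (0.87 log units; beyond the scatter); between the two replacement compounds the step is a 1.7-fold higher number from compound 2 to compound 3 (0.22 log units; within the scatter).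

Compound 4 `CCc1cccc2c(OC)c(-c3occ(C)c3COC(C)=O)ccc12` changes the same position of compound 1: acetoxymethyl in place of methoxycarbonyl on an aromatic carbon. Both measured steps bear on this change, since each of them also removes the methoxycarbonyl group from that aromatic carbon, and each gave a higher number, of modest size and beyond the scatter. Nothing in the measured set points to a lower number on removing this group. A higher number than that of compound 1 is therefore expected for compound 4, of a size similar to the steps seen for compound 2 and compound 3.

For compound 4 in this assay the estimate is 6 ug/mL, with a range from 2 ug/mL to 18 ug/mL. This estimate corresponds to an expected step of a 4.6-fold higher number from compound 1 to compound 4 (0.66 log units; beyond the scatter).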

Compound 4, concentration for half-maximal effect: 3.5 ug/mL
Compound 4: middle estimate off by 1.7-fold (0.23 log units), on the high side, within the range that was stated.
By their numbers in this assay, from the lowest: compound 1; then compounds 4, 2 and 3 (each within the scatter of the next, the first and the last beyond it).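

In this assay, acetoxymethyl joins the other replacements of methoxycarbonyl on this aromatic carbon in giving a higher number than compound 1 (a 2.7-fold higher number from compound 1 to compound 4 (0.43 log units; beyond the scatter)), yet this step is the smallest of the three taken from compound 1, so this change keeps more of the low number of compound 1 than methoxymethyl does. The group on the oxygen also counts at this position: acetyl in place of methyl on an oxygen on a saturated carbon gives a 2.8-fold lower number from compound 3 to compound 4 (0.44 log units; beyond the scatter) and recovers part of the step lost in compound 3, so the two groups joined to the ring through a saturated carbon are not interchangeable. The comparison with the sulfur-containing group gives a 1.7-fold lower number from compound 2 to compound 4 (0.22 log units; within the scatter) and sets no order between those two compounds.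

As far as these compounds go, whether a hydroxymethyl, a carboxylic acid or an amide on this carbon would reach the number of compound 1, and whether a longer ester chain would keep it, stays open. No evidence on the cause of any of these steps is at hand.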